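The source may hold more compounds than are shown below. What is called first, only, known or untested is meant among the compounds shown, and "the series" means these compounds.

Measured so far:
- compound 1, `CCCCCCCCCCCCOc1ccc(C(=O)/C=C/c2c(/C=C/c3ccc(OC)cc3)cc(OC)cc2OC)cc1`: 11.6 ug/mL
- compound 2, `COc1ccc(/C=C/c2cc(OC)cc(OC)c2/C=C/C(=O)c2cccc(Br)c2)cc1`: 13 ug/mL
- compound 3, `COc1ccc(/C=C/c2cc(OC)cc(OC)c2/C=C/C(=O)c2cccc(Cl)c2)cc1`: 9.5 ug/mL

In a functional assay on HepG2 cells (Homo sapiens) for antiproliferative activity, read by MTT assay, with a stated time of 48 h (a lower number here means a stronger inhibitor, a higher number a weaker inhibitor), compound 3 gives 9.5 ug/mL, the lowest of the three numbers, though its gaps to compound 1 and to compound 2 both lie within the scatter, so no ordering among the three can be read from them. Among the compounds with values here, the only measured step that changes one place is a 1.4-fold lower number from compound 2 to compound 3 (0.14 log units; within the scatter), which is within the scatter.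

Compound 4, `COc1ccc(/C=C/c2cc(OC)cc(OC)c2/C=C/C(=O)c2ccc(Cl)cc2)cc1`, is the next member. It differs from compound 3 as follows: 4-chlorophenyl in place of 3-chlorophenyl on a carbonyl carbon. Within the data shown here, no measured pair speaks directly to moving the chlorine from the 3-position to the 4-position of the phenyl on the carbonyl carbon; the one step available, a 1.4-fold lower number from compound 2 to compound 3 (0.14 log units; within the scatter), exchanged one halogen for another at the same place and produced no change beyond the scatter, and the three measured numbers as a whole sit close together. On that basis the expected step is a 1.1-fold higher number from compound 3 to compound 4 (0.02 log units; within the scatter), that is, no change beyond the scatter in this assay. Compound 4 is therefore estimated at 10 ug/mL, with a range from 5 ug/mL to 20 ug/mL.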

Compound 4, half-maximal inhibitory concentration: 13.6 ug/mL
Compound 4: the middle estimate sits 1.4-fold (0.13 log units) below what was measured; the measured number falls inside the stated range.
By their numbers in this assay, from the lowest: compounds 3, 1, 2 and 4 (each within the scatter of the next).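

In this assay, within the data shown here, the exchange of 3-chlorophenyl for 4-chlorophenyl on the carbonyl carbon (a 1.4-fold higher number from compound 3 to compound 4 (0.16 log units; within the scatter)) is the first measured step that relocates the halogen on this phenyl instead of swapping one halogen for another, and it stays within the scatter. The step that alters both the halogen and its location, 4-chlorophenyl in place of 3-bromophenyl (a 1.0-fold higher number from compound 2 to compound 4 (0.02 log units; within the scatter)), also stays within the scatter, so among compound 2, compound 3 and compound 4 neither kind of change separates the numbers, and this holds only for these three halogenated phenyl groups at this one place. Nothing available bears on why the numbers for this change sit so close together.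

Still open, going by these compounds, is whether this place responds at all to a group of another kind, such as an amine or a carboxylic acid on the phenyl, or to a phenyl with no halogen. Also open, on these data alone, is whether a second halogen on the same ring, or a replacement of the ring itself by pyridine, would give a step beyond the scatter.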